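Para-Methoxy on the Aniline of a Phenylpyranone Scaffold

This account rests on a few compounds, and the source may have more. Where it says the series, first, only, none or still open, it means among the compounds named here.

The measured compounds are compound 1 `COc1ccc(Nc2cc(C3CCCCC3)oc(=O)c2)cc1` with 8.32 uM, compound 2 `O=c1cc(Nc2ccccc2)cc(-c2ccccc2)o1` with 0.13 uM, and compound 3 `COc1ccccc1Nc1cc(-c2ccccc2)oc(=O)c1` with 0.35 uM, all in a functional assay on KB cells (Homo sapiens) for cytotoxicity, read by MTT assay, with a stated time of 72 h; a lower number here means that less compound is needed, a higher number that more compound is needed for the effect.

Compound 2 gives the lowest number of the three in this assay. Within the data shown here, compound 3 stands nearest to it, and compound 1 stands furthest away; compound 1 differs from compound 2 in two places, so no single step links them.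

Compound 4 `COc1ccc(Nc2cc(-c3ccccc3)oc(=O)c2)cc1` is derived from compound 2 by one change: methoxy in place of hydrogen on an aromatic carbon. Among the measured compounds shown here, one measured step bears on this change, namely the step from compound 2 to compound 3, where a methoxy was also added in place of a hydrogen on an aromatic carbon: a 2.7-fold higher number from compound 2 to compound 3 (0.43 log units; beyond the scatter). That step gave a modest rise in the number, beyond the scatter. Compound 1 carries a methoxy at the same place as compound 4, but its different group on the shared core means its value shows nothing cleanly separable.

On this basis compound 4 is expected to give a modestly higher number than compound 2, a step of a 2.3-fold higher number from compound 2 to compound 4 (0.36 log units; beyond the scatter). In this assay compound 4 is therefore estimated at 0.3 uM, within a range from 0.1 uM to 0.9 uM.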

Compound 4, concentration for half-maximal effect: 0.16 uM
Estimate against measurement, compound 4: 1.9-fold (0.27 log units) above, within the range that was stated.
By their numbers in this assay, from the lowest: compounds 2 and 4 (each within the scatter of the next); then compound 3; then compound 1.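

Set para to a large group, the methoxy leaves the number in this assay within the scatter (a 1.2-fold higher number from compound 2 to compound 4 (0.09 log units; within the scatter)), whereas a methoxy at another place on the same ring gave a step beyond the scatter (a 2.7-fold higher number from compound 2 to compound 3 (0.43 log units; beyond the scatter)), so among these compounds the outcome of this change differs with its place on the ring. Among these compounds, the new compound also gives the single-place link to the cyclohexyl series that the earlier compounds lacked: with the methoxy held the same, phenyl in place of cyclohexyl brings a large step (a 52-fold lower number from compound 1 to compound 4 (1.72 log units; beyond the scatter)), which shows that this group alone can move the number far more than either methoxy step does. Nothing in the material shown accounts for either result.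

Going by these compounds, whether an amine, a carboxylic acid or a longer chain at this same place would also stay within the scatter of compound 2 remains open. Also open, on these data alone, is whether the step from cyclohexyl to phenyl would be as large on an aniline ring that carries hydrogen in place of the methoxy.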